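A Chloro Substituent on the Anilide of Compound 2

The compounds below may be only part of what the source reports. "The series", "measured", "known", "first", "only" and "open" are said of these compounds alone.

Compound 1, `Cc1noc(C)c1-c1cnc(N)c(Oc2ccc(C(=O)NC3CC3)cc2)n1`: > 100000 nM
Compound 2, `Cc1noc(C)c1-c1cnc(N)c(Oc2ccc(C(=O)Nc3ccccc3)cc2)n1`: 5740 nM

Both compounds were tested in a functional assay on LoVo cells (Homo sapiens) for inhibition, read by MTT assay, with a stated time of 72 h; on this read-out lower numbers stand for stronger inhibition and higher numbers for weaker inhibition. For compound 1 the result is not a number but a limit of the assay, > 100000 nM. Compound 2 gives 5740 nM, the only real number shown. Within the data shown here, the single measured step, an at least 17-fold lower number from compound 1 to compound 2 (1.24 log units; beyond the scatter), is large, and it starts from the limit of > 100000 nM in this assay, at which 1 of the 2 values shown sits.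

Compound 3, `Cc1noc(C)c1-c1cnc(N)c(Oc2ccc(C(=O)Nc3ccc(Cl)cc3)cc2)n1`, has not yet been measured. It differs from compound 2 by chloro in place of hydrogen on an aromatic carbon. Among the measured compounds shown here, no measured step concerns this kind of change: the only step, an at least 17-fold lower number from compound 1 to compound 2 (1.24 log units; beyond the scatter), exchanges one whole group for another on the amide-type nitrogen and says nothing about a chloro added to that ring. The expectation is therefore a step of about a 1.4-fold lower number from compound 2 to compound 3 (0.16 log units; within the scatter), staying within the usual scatter. Compound 3 is estimated at 4000 nM, with a range from 1500 nM to 12000 nM.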

Compound 3, half-maximal inhibitory concentration: 1920 nM
Beside the measured number, compound 3's estimate is 2.1-fold (0.32 log units) above it, within the range that was stated.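

In this assay, a 3.0-fold lower number from compound 2 to compound 3 (0.48 log units; beyond the scatter) shows that the anilide ring does more than tolerate a change: a chloro of 1 heavy atom, placed on the aromatic carbon para to a large group, moves the number beyond the scatter. The earlier step swapped one whole group on the amide-type nitrogen for another, so it could not show that a substituent on the phenyl ring itself counts, nor that this ring carbon is a place where the number responds. Over the two changes together the total is an at least 52-fold lower number from compound 1 to compound 3 (1.71 log units; beyond the scatter), and this figure is only a bound, as compound 1 gives a limit and not a number: the limit of > 100000 nM in this assay, at which 1 of the 3 values shown sits.

From the compounds shown here alone, whether a fluoro, a methyl, a methoxy or a carboxylic acid on the same carbon would move the number in the same direction stays open, as does the outcome of a chloro on the other carbons of that ring. Also open, going by these compounds, is how a second chloro on the ring would add to the first, and whether a longer chain on the amide-type nitrogen could match the 4-chlorophenyl group.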